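The compounds below may be only part of what the source reports. "The series", "measured", "known", "first", "only" and "open" are said of these compounds alone.

Measured compounds:
Compound 1 `COc1cc(C(=O)c2sc(-c3ccc(Cl)cc3)cc2N)cc(OC)c1OC` gives 93 nM in a functional assay on L1210 cells (Mus musculus) for antiproliferative activity; a higher number here means a weaker inhibitor, a lower number a stronger inhibitor.
Compound 2 `COc1cc(C(=O)c2sc(-c3ccc(F)cc3)cc2N)cc(OC)c1OC` gives 20 nM in this assay.

Within the data shown here, compound 2 stands lowest of the two numbers; its nearest neighbour is compound 1, and the single measured step is a 4.7-fold lower number from compound 1 to compound 2 (0.67 log units; beyond the scatter). Compound 3 `COc1cc(C(=O)c2sc(-c3ccncc3)cc2N)cc(OC)c1OC` carries the change (pyridin-4-yl in place of 4-fluorophenyl on an aromatic carbon). Among the measured compounds shown here, no measured step exchanges the six-membered ring itself: the one known step, a 4.7-fold lower number from compound 1 to compound 2 (0.67 log units; beyond the scatter), swaps only the halogen on that ring, so it bears on the position but not on the kind of change. For compound 3 the step is therefore expected to be small or within the scatter, with the direction uncertain and a wide range allowed, expressed as a 2.5-fold higher number from compound 2 to compound 3 (0.40 log units; beyond the scatter). In this assay compound 3 is estimated at 50 nM, expected to fall between 15 nM and 200 nM.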

Compound 3, half-maximal inhibitory concentration: 1810 nM
For compound 3 the middle estimate is 36-fold (1.56 log units) below the measured one, outside the stated range (above it).
By their numbers in this assay, from the lowest: compound 2; then compound 1; then compound 3.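

The position next to the ring sulfur proves far more sensitive to a change of the six-membered ring than to a change of its halogen. In this assay, pyridin-4-yl gives a 91-fold higher number from compound 2 to compound 3 (1.96 log units; beyond the scatter) and a 19-fold higher number from compound 1 to compound 3 (1.29 log units; beyond the scatter), both large steps, while the halogen exchange alone gave only a 4.7-fold lower number from compound 1 to compound 2 (0.67 log units; beyond the scatter). Both halogen-bearing compounds therefore stand well apart from compound 3 on the same core, although nothing shown here accounts for the loss.

Compound 3 loses the halogen and gains a ring nitrogen in one step, so these compounds cannot separate the two changes. A plain phenyl group would address the loss of the halogen alone, and pyridin-3-yl would show whether the place of the ring nitrogen matters.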